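Halogenated pyridinyl sulfonamides on the piperidinyl-piperidine core

This account rests on a few compounds, and the source may have more. Where it says the series, first, only, none or still open, it means among the compounds named here.

The shared core of compound 1 `CC1CCN(C2CCN(S(=O)(=O)c3cccnc3Cl)CC2)CC1` carries a sulfonyl group whose aryl substituent is the variable part. Compound 1 reaches only a limit in a functional assay on DLD-1 cells (Homo sapiens) for antiproliferative activity, read by CellTiter-Glo, with a stated time of 72 h (a higher number here means a weaker inhibitor, a lower number a stronger inhibitor), recorded as > 5000 nM. Compound 2 `Cc1ccc(S(=O)(=O)N2CCC(N3CCC(C)CC3)CC2)cc1C` gives 24 nM in this assay, and compound 3 `CC1CCN(C2CCN(S(=O)(=O)c3ccc(Cl)nc3)CC2)CC1` gives 3700 nM. Of the two numbers shown, compound 3 stands highest; its nearest neighbour is compound 2, with a 150-fold higher number from compound 2 to compound 3 (2.19 log units; beyond the scatter). Exchanging 3,4-dimethylphenyl for a chloropyridinyl ring is large either way, as an at least 200-fold lower number from compound 1 to compound 2 (2.31 log units; beyond the scatter) and a 150-fold higher number from compound 2 to compound 3 (2.19 log units; beyond the scatter) show, whereas exchanging 2-chloropyridin-3-yl for 6-chloropyridin-3-yl, an at least 1.3-fold lower number from compound 1 to compound 3 (0.13 log units; that floor lies within the scatter), stays within scatter; both halopyridinyl compounds sit at or near the limit (the limit of > 5000 nM in this assay, at which 1 of the 3 values shown sits). Compound 4 `CC1CCN(C2CCN(S(=O)(=O)c3cncc(Br)c3)CC2)CC1` differs from compound 3 by 5-bromopyridin-3-yl in place of 6-chloropyridin-3-yl on a sulfonyl sulfur. Among the measured compounds shown here, the only step that bears on it is the chloropyridinyl swap between compound 1 and compound 3, which was within scatter, so no step beyond scatter is expected; no measured step tests bromine in place of chlorine. Compound 4 is therefore expected near 3500 nM, within 1200 nM to 10000 nM. The expected step is a 1.1-fold lower number from compound 3 to compound 4 (0.02 log units; within the scatter).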

Compound 4, half-maximal inhibitory concentration: > 5000 nM
Compound 4 was reported as a limit; the forecaster's own chance of this, stated with the estimate: 30%; middle value at least 1.4-fold (0.15 log units) away from the limit.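

In this assay compound 4 gives > 5000 nM as a limit of the assay and not a number. Placing 5-bromopyridin-3-yl on the sulfonyl sulfur instead of 6-chloropyridin-3-yl gives an at least 1.3-fold higher number from compound 3 to compound 4 (0.13 log units; that floor lies within the scatter) as its step, so bromine here is not separated from the chlorine-bearing ring, while the step to the dimethylphenyl ring remains large, an at least 200-fold higher number from compound 2 to compound 4 (2.31 log units; beyond the scatter) being the reading. The large gap to 3,4-dimethylphenyl now holds for a bromopyridinyl ring as well as for two chloropyridinyl rings, and the halopyridinyl compounds increasingly collect at the top of the range: the limit of > 5000 nM in this assay, at which 2 of the 4 values shown sit.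

The step between the two limits, from compound 1 to compound 4, cannot be read. Still open, going by these compounds, is whether the gap follows the ring nitrogen or the halogen, a question that a plain phenyl, a bromophenyl or a dimethylpyridinyl ring on the sulfonyl sulfur would address.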